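A few compounds are considered here, and "the series" means these few. Any claim that something is new, unique, unknown or untested is made for them only; others in the source may bear on it.

Measured so far:
compound 1 `O=C(CCCCCCc1ccccc1)c1ncc(-c2cccc(O)c2)o1`, which in an assay (Rattus norvegicus) for inhibition of Fatty-acid amide hydrolase 1 (Homo sapiens) (on this read-out lower numbers stand for stronger inhibition and higher numbers for weaker inhibition), gives 50 nM
compound 2 `Cc1ccnc(-c2cnc(C(=O)CCCCCCc3ccccc3)o2)c1`, which gives 0.6 nM
compound 3 `NS(=O)(=O)c1ccc(-c2cnc(C(=O)CCCCCCc3ccccc3)o2)s1`, which gives 3 nM

Compound 3 stands second highest of the three numbers; compound 2 is nearest to it, a 5.0-fold higher number from compound 2 to compound 3 (0.70 log units; beyond the scatter), and compound 1 furthest, a 17-fold lower number from compound 1 to compound 3 (1.22 log units; beyond the scatter). Compound 4 `CN1CCN(C(=O)c2cnc(C(=O)CCCCCCc3ccccc3)o2)CC1` differs from compound 3 by (4-methylpiperazin-1-yl)carbonyl in place of 5-sulfamoylthiophen-2-yl on an aromatic carbon. Going by the values given here, no measured step exchanges an aromatic group for a carbonyl-linked group at this position; the steps that come closest vary the aromatic group itself, an 83-fold lower number from compound 1 to compound 2 (1.92 log units; beyond the scatter) and a 17-fold lower number from compound 1 to compound 3 (1.22 log units; beyond the scatter), and show that this position can move the number a great deal. Without a direct precedent, a modest step upward is expected, a 5.0-fold higher number from compound 3 to compound 4 (0.70 log units; beyond the scatter), and compound 4 is estimated at 15 nM, between 2 nM and 120 nM.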

Compound 4, inhibition constant: 80 nM
The estimate for compound 4 lay 5.3-fold (0.73 log units) below the measured number; low and high end bracket the measured number.
By their numbers in this assay, from the lowest: compound 2; then compound 3; then compounds 1 and 4 (each within the scatter of the next).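

Placed on this carbon, the carbonyl-linked non-aromatic ring of (4-methylpiperazin-1-yl)carbonyl gives a large loss against two of the aromatic groups: a 27-fold higher number from compound 3 to compound 4 (1.43 log units; beyond the scatter) and a 130-fold higher number from compound 2 to compound 4 (2.12 log units; beyond the scatter). Against 3-hydroxyphenyl it gives no distinguishable change, a 1.6-fold higher number from compound 1 to compound 4 (0.20 log units; within the scatter), so this position accepts a non-aromatic group only at the level of the weaker aromatic compound shown. No evidence at hand bears on the reason for these differences. Going by these compounds, it remains open whether the carbonyl or the piperazine ring sets this number, and how a morpholine amide or a carboxylic acid here would compare.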